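Isopropyl amide replaces pyridyl amide on the piperazine

The source may report more compounds than this note shows. Statements on the series, on what has been measured and on what is new or still open speak of the compounds shown alone.

Three compounds from one series have been examined in an assay on isolated protein for inhibition of aldehyde dehydrogenase 1A1 (Homo sapiens), read by spectrophotometry, tested at 10 uM; a lower number here means less inhibition, a higher number more inhibition at the concentration tested (going by the name of the read-out). Compound 1 `CC(C)CCn1c(OC2CCN(C(=O)c3ccco3)CC2)nc2ccccc21` gives 30.8%, compound 2 `Cc1cccc(Cn2c(CN3CCN(C(=O)c4ccncc4)CC3)nc3ccccc32)c1` gives 20.6%, and compound 3 `O=C(C1CC1)N1CCN(Cc2nc3ccccc3n2Cc2ccc(Cl)cc2)CC1` gives 56.6%. Compound 2 thus stands lowest of the three: its nearest neighbour is compound 1, a gap beyond the usual scatter, and compound 3 lies furthest from it, again beyond the scatter. Compound 4 `Cc1cccc(Cn2c(CN3CCN(C(=O)C(C)C)CC3)nc3ccccc32)c1` has not yet been measured in this assay. It differs from compound 2 in a single place: isopropyl in place of pyridin-4-yl on a carbonyl carbon. Within the data shown here, no two measured compounds are separated by exactly one change, so the size of this step cannot be read off directly. Compound 3 differs from compound 2 in more than one place, yet in this assay compound 3 gives 56.6%, a considerably higher number than compound 2, and the change toward compound 4 runs in a broadly similar direction. A moderate rise is therefore expected, a number 12.4 percentage points higher from compound 2 to compound 4 (beyond the scatter), with real uncertainty. Compound 4 is estimated to give 33%, within a range from 15% to 55%.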

Compound 4, a percentage reported as inhibition, at one concentration (the size of the read-out at that concentration, not a potency): 87.2%
For compound 4 the middle estimate is 54.2 percentage points below the measured one, and the stated range ends below it.
By their numbers in this assay, from the lowest: compound 2; then compound 1; then compound 3; then compound 4.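

In this assay, among these compounds, isopropyl in place of pyridin-4-yl on a carbonyl carbon gives a number 66.6 percentage points higher from compound 2 to compound 4 (beyond the scatter), the first step that can be read at a single place. It shows that this position, on a carbonyl carbon whose other neighbours are an amide-type nitrogen in a ring, has a large bearing on the read-out, and that here the higher number goes with the group that has no ring. Nothing available accounts for a step of this size.

From the compounds shown here alone, it remains open whether the rise goes with the loss of the aromatic ring or with the loss of its nitrogen, which a phenyl group at this place would help to separate. The compounds shown also leave open how a tert-butyl group or a longer chain such as n-butyl would compare with isopropyl on the same carbonyl carbon.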